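This account rests on a few compounds, and the source may have more. Where it says the series, first, only, none or still open, it means among the compounds named here.

Three measured compounds share one core and differ only in the group attached to an oxygen on a saturated carbon. In a functional assay on HeLa cells (Homo sapiens) for cytotoxicity, read by MTT assay (on this read-out higher numbers stand for weaker inhibition and lower numbers for stronger inhibition), compound 1 `COC(C)CO[C@H](CC=C(C)C)C1=CC(=O)c2c(O)ccc(O)c2C1=O` gives 53400 nM, compound 2 `CC(=O)OCCO[C@H](CC=C(C)C)C1=CC(=O)c2c(O)ccc(O)c2C1=O` gives 41500 nM, and compound 3 `CCC(C)(O)CC(=O)O[C@H](CC=C(C)C)C1=CC(=O)c2c(O)ccc(O)c2C1=O` gives 25200 nM. Compound 2 thus sits second highest of the three, with a 1.3-fold lower number from compound 1 to compound 2 (0.11 log units; within the scatter) and a 1.6-fold lower number from compound 2 to compound 3 (0.22 log units; within the scatter), while a 2.1-fold lower number from compound 1 to compound 3 (0.33 log units; beyond the scatter). Compound 4 `CC(C)=CC[C@@H](OC(=O)c1ccoc1)C1=CC(=O)c2c(O)ccc(O)c2C1=O` is not yet measured; it differs from compound 2 by (furan-3-yl)carbonyl in place of 2-acetoxyethyl on an oxygen on a saturated carbon. The two steps at this oxygen that touch compound 2 were both small, so in this assay only a small shift is expected, likely a 1.3-fold lower number from compound 2 to compound 4 (0.11 log units; within the scatter). Compound 4 is therefore estimated at 32000 nM, within a range from 13000 nM to 80000 nM.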

Compound 4, half-maximal inhibitory concentration: > 100000 nM
Compound 4: no number, only a limit; the forecaster's own chance of this, stated with the estimate: 10%; middle value at least 3.1-fold (0.49 log units) from the limit.
By their numbers in this assay, from the lowest: compounds 3, 2 and 1 (each within the scatter of the next, the first and the last beyond it). At a limit, above all of these: compound 4.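

In this assay, compound 4 yields only a limit: the limit of > 100000 nM in this assay, at which 1 of the 4 values shown sits.

Unlike the earlier changes at this oxygen, this one moves the read-out clearly towards weaker inhibition, with an at least 2.4-fold higher number from compound 2 to compound 4 (0.38 log units; beyond the scatter) and an at least 3.9-fold higher number from compound 3 to compound 4 (0.59 log units; beyond the scatter), while an at least 1.8-fold higher number from compound 1 to compound 4 (0.27 log units; that floor lies within the scatter) leaves the comparison with compound 1 unsettled. Among the compounds shown, only compound 4 carries a ring in this group, so this position does not accept every acyl change without loss.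

As far as these compounds go, how far compound 4 lies past its limit stays open. So does whether the loss belongs to furan-3-yl alone or would also follow with a phenyl or cyclohexyl group on the same carbonyl.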